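Working notes: cyclopropyl in place of cyclobutyloxy

The source may hold more compounds than are shown below. What is called first, only, known or untested is meant among the compounds shown, and "the series" means these compounds.

Values measured in a toxicity assay on microsomes from liver (Homo sapiens) for metabolic stability, read by LC-MS, using NADPH, tested at 1 uM (a lower number here means slower removal, a higher number faster removal of the compound), are:
compound 1 `CCOc1ncc(-c2nc(C(F)(F)F)sc2N2CCN(C(=O)Cn3ccc4cccnc43)[C@H](C)C2)cn1` gives 316 mL.min-1.g-1
compound 2 `CCOc1ncc(-c2nc(C(F)(F)F)sc2N2CCN(C(=O)Cn3nc(C)cc3C)[C@H](C)C2)cn1` gives 184 mL.min-1.g-1
compound 3 `Cc1nc(C)n(CC(=O)N2CCN(c3sc(C(F)(F)F)nc3-c3cnc(OC4CCC4)nc3)C[C@H]2C)n1` gives 51 mL.min-1.g-1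

Compound 3 (at 51 mL.min-1.g-1) holds the lowest of the three numbers, and compound 2 and compound 1 both lie higher by more than the scatter. The next structure is compound 4 `Cc1nc(C)n(CC(=O)N2CCN(c3sc(C(F)(F)F)nc3-c3cnc(C4CC4)nc3)C[C@H]2C)n1` which carries cyclopropyl in place of cyclobutyloxy on an aromatic carbon, between two ring nitrogen atoms (difference: cyclopropyl in place of cyclobutyloxy on an aromatic carbon). Among the compounds with values here, the only measured one-place step (that is a 1.7-fold lower number from compound 1 to compound 2 (0.23 log units; within the scatter)) lies on a saturated chain carbon bound to a carbonyl carbon, not at the place of this change, and stays within the scatter. Within the data shown here, no measured step covers a change at this place, so that step offers only weak guidance. Starting from compound 3 (at 51 mL.min-1.g-1) no shift beyond the scatter is expected in this assay and no direction can be favoured. The expected step (that is a 1.1-fold lower number from compound 3 to compound 4 (0.05 log units; within the scatter)) is an estimate only. For compound 4 the estimated value is 45 mL.min-1.g-1 with an expected range from 18 mL.min-1.g-1 to 110 mL.min-1.g-1 and this range is kept wide, as no closer comparison exists.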

Compound 4, intrinsic clearance in microsomes: < 10 mL.min-1.g-1
Compound 4 was reported as a limit; the forecaster's own chance of this, stated with the estimate: 10%; middle value at least 4.5-fold (0.65 log units) away from the limit.
By their numbers in this assay, from the lowest: compound 3; then compounds 2 and 1 (each within the scatter of the next). At a limit, below all of these: compound 4.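

Working notes, continued: this position responds in this assay, where cyclopropyl in place of cyclobutyloxy, on an aromatic carbon between two ring nitrogen atoms, gives an at least 5.1-fold lower number from compound 3 to compound 4 (0.70 log units; beyond the scatter). Within the data shown here, the earlier compounds held no step at this place; their only one-place step, a 1.7-fold lower number from compound 1 to compound 2 (0.23 log units; within the scatter), lies on a saturated chain carbon bound to a carbonyl carbon and stays within the scatter, which makes the new step the first one-place change in this set to go beyond it. The value of compound 4 is a limit of the assay and not a number: the limit of < 10 mL.min-1.g-1 in this assay, at which 1 of the 4 values shown sits.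

This single pair does not separate the loss of the oxygen from the change from a four-membered to a three-membered ring, and it does not show whether the same step would appear with the groups of compound 1 or compound 2 on the chain carbon. From the compounds shown here alone, how other groups at this aromatic carbon would read in this assay also stays open, for example an amine, a carboxylic acid or a longer chain.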